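Swapping Chloro for Methyl on the Benzyl Group

The source may report more compounds than this note shows. Statements on the series, on what has been measured and on what is new or still open speak of the compounds shown alone.

Among the measured compounds shown here, compound 2 `COC(=O)C1C(=O)C(C(=O)OC)[C@H](c2cccc([N+](=O)[O-])c2)N(Cc2ccc(Cl)cc2)[C@@H]1c1cccc([N+](=O)[O-])c1` is the only measured compound here that gives an actual number in an ADME assay on J774.1 cells (Mus musculus) for cytotoxicity, with a stated time of 48 h; on this read-out lower numbers stand for an effect already at smaller amounts and higher numbers for an effect only at larger amounts of compound; in this assay compound 2 gives 46.6 uM. Compound 1 `COC(=O)C1C(=O)C(C(=O)OC)[C@H](c2cccc([N+](=O)[O-])c2)N(Cc2ccccc2)[C@@H]1c1cccc([N+](=O)[O-])c1` carries a plain hydrogen where compound 2 carries chloro. In this assay compound 1 gives only a limit, > 100 uM. That limit is the one at which one of the two values shown sits, (the limit of > 100 uM in this assay, at which 1 of the 2 values shown sits). For the measured compounds named here, the single measured step, an at least 2.1-fold lower number from compound 1 to compound 2 (0.33 log units; beyond the scatter), is thus known only as a lower bound for its size.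

Compound 3 `COC(=O)C1C(=O)C(C(=O)OC)[C@H](c2cccc([N+](=O)[O-])c2)N(Cc2ccc(C)cc2)[C@@H]1c1cccc([N+](=O)[O-])c1` arises from compound 2 by methyl in place of chloro on an aromatic carbon. Going by the values given here, no measured step compares methyl with chloro directly; the step from compound 1 to compound 2 shows only that placing chloro there moved the number down by at least a modest amount. Exchanging one small group for another is therefore expected to give a step that stays within the scatter, if anything a slightly higher number, a 1.3-fold higher number from compound 2 to compound 3 (0.11 log units; within the scatter). Compound 3 is estimated at 60 uM in this assay, within a range from 25 uM to 140 uM.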

Compound 3, concentration for half-maximal effect: 49.8 uM
Compound 3: the middle estimate sits 1.2-fold (0.08 log units) above what was measured; the measured number falls inside the stated range.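

In this assay the exchange of chloro for methyl gives a 1.1-fold higher number from compound 2 to compound 3 (0.03 log units; within the scatter) and leaves compound 2 and compound 3 indistinguishable. This adds something the earlier step could not show: at this position on the benzyl group, two different small groups, one built on chlorine and one on carbon, give numbers that match within normal repeat-to-repeat variation. Against hydrogen, methyl gives an at least 2.0-fold lower number from compound 1 to compound 3 (0.30 log units; that floor lies within the scatter) and that floor alone does not establish a real shift, so any effect of methyl relative to hydrogen remains unproven, and the comparison rests on a value for compound 1 that is only a limit: the limit of > 100 uM in this assay, at which 1 of the 3 values shown sits.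

As far as these compounds go, the true size of any step away from hydrogen stays open, as does whether the reading of this assay would stay the same with a methoxy group, an amine, a carboxylic acid or a longer chain at this position. From the compounds shown here alone, it is also open whether chloro and methyl would match in the same way elsewhere on the benzyl ring.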